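Removing the ethyl from compound 1: expected potency

This account rests on a few compounds, and the source may have more. Where it says the series, first, only, none or still open, it means among the compounds named here.

Of the compounds shown here, two have numbers so far. Compound 1 `CCc1cc(C/N=c2\c(O)c(O)\c2=N/C(C)(C)C)ccc1C#N` gives 6100 nM in a functional assay for inhibition, with Rattus norvegicus as the target (on this read-out lower numbers stand for stronger inhibition and higher numbers for weaker inhibition), the higher of the two numbers. Compound 2 `CCC(C)(C)/N=c1\c(O)c(O)\c1=N/Cc1c(C)cc(C#N)cc1Cl` gives 160 nM in this assay, and the gap between compound 1 and compound 2 lies beyond the scatter, so compound 2 is the stronger inhibitor of the pair; compound 2 differs from compound 1 in several places, so no single change can be read from that pair.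

Compound 3 `CC(C)(C)/N=c1\c(O)c(O)\c1=N/Cc1ccc(C#N)cc1` has not been measured. It differs from compound 1 in one place: hydrogen in place of ethyl on an aromatic carbon.

Among the measured compounds shown here, no single-point step is known, so the size of this change rests on judgement alone. The change moves toward a less substituted ring, away from the more substituted compound 2, and a step of modest size toward weaker inhibition, or none beyond the scatter, is expected; the estimated step from compound 1 to compound 3 is a 1.3-fold higher number from compound 1 to compound 3 (0.12 log units; within the scatter). Compound 3 is estimated at 8000 nM in this assay, within a range of 2500 nM to 25000 nM.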

Compound 3, half-maximal inhibitory concentration: 270 nM
Beside the measured number, compound 3's estimate is 30-fold (1.47 log units) above it; the whole stated range lies above it.
By their numbers in this assay, from the lowest: compounds 2 and 3 (each within the scatter of the next); then compound 1.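

In this assay this position, on an aromatic carbon ortho to a cyano group, now has its first single-change reading: hydrogen in place of ethyl gives a 23-fold lower number from compound 1 to compound 3 (1.35 log units; beyond the scatter) and so counts as a large step. The position is therefore not indifferent to substitution, and in this pair the unsubstituted carbon carries the stronger inhibition. No measurement at hand bears on the reason for this step.

One step cannot show whether inhibition falls steadily with the size of the group here or whether ethyl alone is poorly tolerated, so a fluorine, a methoxy or a longer chain such as propyl at this carbon would be informative. On these data alone, whether the step keeps its size with other substitution on the ring also remains open.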